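The source may hold more compounds than are shown below. What is called first, only, known or untested is meant among the compounds shown, and "the series" means these compounds.

In a functional assay on Jurkat cells (Homo sapiens) (on this read-out higher numbers stand for weaker inhibition and lower numbers for stronger inhibition), three compounds built on the same core have been measured, and they differ only in the group on an oxygen on a saturated carbon. Compound 1 `CC(C)[C@H](NC(=O)COc1cccc2ccccc12)C(=O)N[C@@H](CC(=O)O)C(=O)COC(=O)c1c(Cl)cccc1Cl`, carrying (2,6-dichlorophenyl)carbonyl there, gives 10600 nM. Compound 2 `CC(C)[C@H](NC(=O)COc1cccc2ccccc12)C(=O)N[C@@H](CC(=O)O)C(=O)COc1cccc(F)c1`, carrying 3-fluorophenyl, reaches only the assay's limit, > 100000 nM. Compound 3 `CC(C)[C@H](NC(=O)COc1cccc2ccccc12)C(=O)N[C@@H](CC(=O)O)C(=O)COc1c(F)ccc(F)c1F`, carrying 2,3,6-trifluorophenyl, gives 1200 nM, the lowest number of the set.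

Compound 4 `CC(C)[C@H](NC(=O)COc1cccc2ccccc12)C(=O)N[C@@H](CC(=O)O)C(=O)COc1cccc(C(F)(F)F)c1F` has 2-fluoro-3-(trifluoromethyl)phenyl in place of 2,3,6-trifluorophenyl on that same oxygen: 2-fluoro-3-(trifluoromethyl)phenyl in place of 2,3,6-trifluorophenyl on an oxygen on a saturated carbon. Among the compounds with values here, the closest precedent is an at least 83-fold lower number from compound 2 to compound 3 (1.92 log units; beyond the scatter), a large step between two fluorinated phenyl groups, although one end of it is a limit. The step of an 8.8-fold lower number from compound 1 to compound 3 (0.95 log units; beyond the scatter) is modest. Together they show that this position can shift the number widely, but no measured compound carries a trifluoromethyl, so the size of the next step remains uncertain. Since compound 3 already stands lowest at 1200 nM, a modest move towards a higher number, meaning weaker inhibition, is expected, and the estimated step is a 3.3-fold higher number from compound 3 to compound 4 (0.52 log units; beyond the scatter). For compound 4 the estimated value is 4000 nM, with an expected range from 700 nM to 30000 nM.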

Compound 4, half-maximal inhibitory concentration: 50400 nM
The estimate for compound 4 lay 13-fold (1.10 log units) below the measured number, outside the stated range (above it).
By their numbers in this assay, from the lowest: compound 3; then compound 1; then compound 4. At a limit, above all of these: compound 2.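

Replacing 2,3,6-trifluorophenyl with 2-fluoro-3-(trifluoromethyl)phenyl gives a 42-fold higher number from compound 3 to compound 4 (1.62 log units; beyond the scatter), so this position is now shown to respond strongly to a change between two fluorinated phenyl groups with both ends measured as numbers, and the carbon and fluorine added in the new group do not lower the number here. The comparison with the (2,6-dichlorophenyl)carbonyl group gives a 4.8-fold higher number from compound 1 to compound 4 (0.68 log units; beyond the scatter), which shows that a fluorinated phenyl group on this oxygen does not by itself give a lower number than that group: compound 3 falls below compound 1, whereas compound 4 lies above it. The remaining comparison rests on a limit, so the step of an at least 1.9-fold lower number from compound 2 to compound 4 (0.29 log units; that floor lies within the scatter) is only a floor that does not separate the two: the limit of > 100000 nM in this assay, at which 1 of the 4 values shown sits.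

The compounds shown leave open which part of the exchange carries the large step, since the two rings differ in more than one substituent. Going by these compounds, it also remains open whether a smaller group such as a methyl, a chlorine or a nitrile in place of the trifluoromethyl would keep the number near that of compound 3.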